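The source may report more compounds than this note shows. Statements on the series, on what has been measured and on what is new or still open speak of the compounds shown alone.

Two measured compounds set the scene. In a functional assay on a cell-free system (Platelet, plasma, Homo sapiens) for inhibition (a higher number here means a weaker inhibitor, a lower number a stronger inhibitor), compound 1, `O=C(NC[C@H](NS(=O)(=O)c1ccccc1)C(=O)O)c1ccc(N2CCC[C@H](NC3=NCCCN3)C2)cc1F`, gives 290 nM, while compound 2, `O=C(NC[C@H](NS(=O)(=O)c1ccccc1)C(=O)O)c1ccc(N2CCC(NC3=NCCCN3)CC2)c(Cl)c1`, gives 90 nM. Compound 2 therefore holds the lower of the two numbers, and its gap to compound 1 lies beyond the usual scatter. These two compounds differ in more than one place, so they offer no clean single-change comparison.

The next compound, compound 3, `O=C(NC[C@H](NS(=O)(=O)c1ccccc1)C(=O)O)c1ccc(N2CCC(NC3=NCCCN3)CC2)c(O)c1`, departs from compound 2 in one substituent: hydroxy in place of chloro on an aromatic carbon. This puts hydroxy in place of chloro on an aromatic carbon, ortho to a large group and meta to a large group. Among the measured compounds shown here, no measured pair shows this exchange, so the expectation rests only on the change itself and on compound 2 at 90 nM. A small step toward a higher number in this assay is expected, one that may not clear the scatter. The estimated shift is a 1.7-fold higher number from compound 2 to compound 3 (0.22 log units; within the scatter). For compound 3 the expected value is 150 nM, with an estimated range of 40 nM to 500 nM.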

Compound 3, half-maximal inhibitory concentration: 170 nM
Compound 3: middle estimate off by 1.1-fold (0.05 log units), on the low side, within the range that was stated.
By their numbers in this assay, from the lowest: compounds 2, 3 and 1 (each within the scatter of the next, the first and the last beyond it).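

In this assay, among the compounds shown here, hydroxy in place of chloro on an aromatic carbon, ortho to a large group and meta to a large group, gives a 1.9-fold higher number from compound 2 to compound 3 (0.28 log units; within the scatter) and provides the first comparison in this set in which only one place differs. At this position, the assay therefore does not separate the two groups, even though the entering hydroxy carries 1 hydrogen-bond donor and 1 hydrogen-bond acceptor, while the departing chloro carries neither. No independent evidence bears on how this result arises.

On these data alone, whether a methoxy group or an amine at the same position would stay within the scatter of compound 2 or move beyond it remains open. As far as these compounds go, compound 1 differs from compound 2 and compound 3 in more than one place, so it remains unknown which of its differences matter in this assay, or whether hydroxy in place of chloro would give a similar step on the core of compound 1.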